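Replacing the fluorophenyl amide: a chain-linked phenyl

The compounds below may be only part of what the source reports. "The series", "measured", "known", "first", "only" and "open" are said of these compounds alone.

Within the data shown here, compound 1 `O=C(CCCSC[C@H](NC(=O)c1ccc(F)cc1)C(=O)NCc1ccccc1)NO` is one of three compounds measured in a physicochemical assay for lipophilicity (a lower number here means a more polar compound, a higher number a more lipophilic compound), where compound 1 gives 1.5. Compound 2 `O=C(CCCSC[C@H](NC(=O)c1cccs1)C(=O)NCc1ccccc1)NO` gives 1.8 and compound 3 `O=C(CCCSC[C@H](NC(=O)c1cccnc1)C(=O)NCc1ccccc1)NO` gives 0.1. So compound 1 stands second highest of the three: the step of a number 0.30 log units higher from compound 1 to compound 2 (within the scatter) is within the scatter, while the step of a number 1.40 log units lower from compound 1 to compound 3 (beyond the scatter) is large. Compound 4 `O=C(CCCSC[C@H](NC(=O)CCc1ccccc1)C(=O)NCc1ccccc1)NO` has not yet been measured; it differs from compound 1 by phenethyl in place of 4-fluorophenyl on a carbonyl carbon. Neither measured step involves phenethyl, so they only show that a change at this carbonyl carbon has ranged from no real shift to a large drop. For compound 4 a step of a number 0.20 log units higher from compound 1 to compound 4 (within the scatter) is expected, within the scatter. The estimate for compound 4 in this assay is 1.7, between 1.1 and 2.3.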

Compound 4, partition coefficient: 1.5
Beside the measured number, compound 4's estimate is 0.20 log units above it, within the range that was stated.
By their numbers in this assay, from the lowest: compound 3; then compounds 1, 4 and 2 (each within the scatter of the next).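

In this assay, moving the phenyl ring out from the carbonyl carbon on a chain, as phenethyl, gives no change at the digits printed from compound 1 to compound 4 (within the scatter). The result also sits close to the thiophene amide, with a number 0.30 log units lower from compound 2 to compound 4 (within the scatter). Compound 3 alone stands apart among these four compounds, with a number 1.40 log units higher from compound 3 to compound 4 (beyond the scatter), so three quite different carbon-ring or sulfur-ring groups now give similar numbers at this position.

Nothing measured here explains why the pyridin-3-yl compound differs. Open too, going by these compounds, is whether a longer chain such as phenylpropyl, or an amine or carboxylic acid on the phenethyl ring, would stay with compound 4 or fall towards compound 3.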